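A few compounds are considered here, and "the series" means these few. Any claim that something is new, unique, unknown or untested is made for them only; others in the source may bear on it.

Compound 1 `Clc1ccc(-c2cc(-c3ccsc3)nc(-c3ccccc3Cl)c2)o1` gives 17200 nM in a functional assay on K562 cells (Homo sapiens) for cytotoxicity, in the presence of a further agent that is not named here; on this read-out higher numbers stand for weaker inhibition and lower numbers for stronger inhibition.
Compound 2 `Clc1ccc(-c2cc(-c3cccs3)nc(-c3ccccc3Cl)c2)o1` gives 17200 nM in this assay.

In this assay, among the measured compounds shown here, compound 2 stands level with compound 1; the only measured step, no change at the digits printed from compound 1 to compound 2 (within the scatter), stays within the scatter. Compound 3 `Clc1ccc(-c2cc(-c3ccc(Cl)o3)cc(-c3cccs3)n2)cc1` differs from compound 2 by 4-chlorophenyl in place of 2-chlorophenyl on an aromatic carbon. For the measured compounds named here, no measured step alters the chlorophenyl group; the one known step concerns the thiophene and left the read-out unchanged. The expected step is therefore none beyond the scatter: a 1.0-fold lower number from compound 2 to compound 3 (0.01 log units; within the scatter). Compound 3 is estimated at 17000 nM, with a range from 6000 nM to 50000 nM.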

Compound 3, half-maximal inhibitory concentration: 20900 nM
Compound 3: the middle estimate sits 1.2-fold (0.09 log units) below what was measured; the measured number falls inside the stated range.
By their numbers in this assay, from the lowest: compounds 1, 2 and 3 (each within the scatter of the next).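

In this assay, 4-chlorophenyl in place of 2-chlorophenyl, next to the ring nitrogen, gives a 1.2-fold higher number from compound 2 to compound 3 (0.08 log units; within the scatter) and so stays within the scatter. Among the compounds shown here, this is the first measured change to this group, as the earlier step touched only the thiophene, and moving the chlorine around this phenyl ring leaves the read-out level here. Nothing measured bears on why this is so.

From the compounds shown here alone, both groups at this position are chlorophenyl, so it remains open whether the read-out would respond to a different substituent on the phenyl ring, such as an amine or a carboxylic acid. The same question holds for replacing the phenyl ring with a longer chain.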